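A few compounds are considered here, and "the series" means these few. Any claim that something is new, unique, unknown or untested is made for them only; others in the source may bear on it.

Compound 1 (`C=C1CC[C@@H]2[C@](C)(CCC[C@]2(C)C(=O)OC)[C@H]1CCc1ccc2c(OC)ccc(OC)c2c1`) stands at > 6700 nM in a functional assay on HT-29 cells (Homo sapiens) for cytotoxicity, read by sulforhodamine B assay, with a stated time of 72 h (on this read-out higher numbers stand for weaker inhibition of growth and lower numbers for stronger inhibition of growth), and that value is a limit, not a number. Compound 2 (`C=C1CC[C@@H]2[C@](C)(CCC[C@]2(C)C(=O)O)[C@H]1CCC1=CCc2c(OC(C)=O)ccc(OC(C)=O)c2C1`) gives 10100 nM in this assay as a measured number. The change from compound 1 to compound 3 (`C=C1[C@H](O)C[C@@H]2[C@](C)(CCC[C@]2(C)C(=O)OC)[C@H]1CCc1ccc2c(OC)ccc(OC)c2c1`) is hydroxy in place of hydrogen on a saturated ring carbon and amounts to hydroxy in place of hydrogen on a saturated ring carbon. Among the compounds with values here, no measured pair shows this change, so no step beyond the scatter is expected in this assay and no direction is favoured. The estimated change is a step that the limit leaves unreadable from compound 1 to compound 3 and nothing larger is expected. For compound 3 the expected value is 9000 nM within an estimated range of 3000 nM to 30000 nM overall.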

Compound 3, concentration for 50% growth inhibition: > 6400 nM
Compound 3 was reported as a limit; the forecaster's own chance of this, stated with the estimate: 45%; the middle value lies beyond the limit too.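

No step can be read from compound 1 to compound 3 in this assay, as both results are limits. As far as these compounds go, whether hydroxy in place of hydrogen on a saturated ring carbon shifts growth inhibition, and in which direction, stays open.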